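The source may report more compounds than this note shows. Statements on the series, on what has been measured and on what is new or still open speak of the compounds shown alone.

Measured so far:
Compound 1 `CN(C)C(=O)c1ccncc1Nc1cc(-c2ccc3ccn(C)c3c2)c2nccnc2c1` gives 499 nM in an assay for inhibition of 6-phosphofructo-2-kinase/fructose-2,6-bisphosphatase 3 (Homo sapiens), read by ADP-Glo, with a stated time of 2 h; a lower number here means a stronger inhibitor, a higher number a weaker inhibitor.
Compound 2 `CN1CCC(NC(=O)c2ccncc2Nc2cc(-c3ccc4ccn(C)c4c3)c3nccnc3c2)CC1` gives 38 nM in this assay.

Among the compounds with values here, compound 2 holds the lowest of the two numbers in this assay; its nearest neighbour is compound 1, and the single measured step is a 13-fold lower number from compound 1 to compound 2 (1.12 log units; beyond the scatter), which changes the group on the carbonyl carbon.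

Compound 3 `CC(=O)N1CCC(NC(=O)c2ccncc2Nc2cc(-c3ccc4ccn(C)c4c3)c3nccnc3c2)CC1` keeps the whole of compound 2 and differs in one place: acetyl in place of methyl on an amine nitrogen in a ring. Within the data shown here, no measured step touches this position; the one step known concerns the carbonyl substituent and offers no direct guide to swapping methyl for acetyl on the ring nitrogen. With nothing measured at this position, the working expectation is a small step, probably toward a higher number, of roughly a 2.0-fold higher number from compound 2 to compound 3 (0.30 log units; within the scatter), within or near the scatter. Compound 3 is therefore estimated at 75 nM in this assay, with a range from 20 nM to 280 nM.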

Compound 3, half-maximal inhibitory concentration: 18 nM
For compound 3 the middle estimate is 4.2-fold (0.62 log units) above the measured one, and the stated range ends above it.
By their numbers in this assay, from the lowest: compound 3; then compound 2; then compound 1.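

In this assay acetyl in place of methyl on the amine nitrogen in the ring gives a 2.1-fold lower number from compound 2 to compound 3 (0.32 log units; beyond the scatter) and this modest step shows that the methyl is not needed at this position and that the larger acetyl is accepted there. Taken with the change on the carbonyl carbon, the replacement of dimethylamino by (1-acetylpiperidin-4-yl)amino gives a 28-fold lower number from compound 1 to compound 3 (1.44 log units; beyond the scatter) as the largest step in the series so far. No evidence bears on why acetyl gives the lower number.

Still open, from the compounds shown here alone, is whether the carbonyl of the acetyl matters or only the loss of methyl, a question that the free ring amine, a methanesulfonyl group or a longer acyl chain such as propanoyl on the same nitrogen would address. Going by these compounds, whether the ring itself is needed also stays open, and an open-chain amine on the amide nitrogen would test this.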